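Benzyl to phenyl on the thiazole carboxamide nitrogen

A few compounds are considered here, and "the series" means these few. Any claim that something is new, unique, unknown or untested is made for them only; others in the source may bear on it.

Within the data shown here, in a functional assay on HeLa cells (Homo sapiens) for cytotoxicity, read by MTT assay, with a stated time of 48 h, in the presence of a further agent that is not named here (on this read-out higher numbers stand for weaker inhibition and lower numbers for stronger inhibition), compound 1 `O=C(NCc1ccccc1)c1csc(-c2c[nH]c3ccccc23)n1` gives 41400 nM, the highest of the two numbers measured so far. Among the measured compounds shown here, compound 2 `COc1ccc2[nH]cc(-c3nc(C(=O)Nc4cc(OC)c(OC)c(OC)c4)cs3)c2c1` gives 9980 nM in this assay, a lower number that lies beyond the scatter; the two compounds differ in more than one place, so no single step connects them. Compound 3 `O=C(Nc1ccccc1)c1csc(-c2c[nH]c3ccccc23)n1` differs from compound 1 in one place only: phenyl in place of benzyl on an amide-type nitrogen. For the measured compounds named here, no measured pair shows this change, so its size is not known from the data. The expectation for this assay is a step of a 1.5-fold lower number from compound 1 to compound 3 (0.17 log units; within the scatter), towards a somewhat lower number, but not clearly beyond the scatter. Compound 3 is accordingly expected to give about 28000 nM in this assay, with a range from 9000 nM to 90000 nM.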

Compound 3, half-maximal inhibitory concentration: > 100000 nM
Compound 3 ended at the assay's limit; the forecaster's own chance of this, stated with the estimate: 10%; middle value at least 3.5-fold (0.55 log units) from the limit.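

In this assay compound 3 gives > 100000 nM, which is a limit of the assay and not a number. Phenyl in place of benzyl on the amide-type nitrogen gives an at least 2.4-fold higher number from compound 1 to compound 3 (0.38 log units; beyond the scatter), the first measured step at this position, and it shows that the benzyl of compound 1 cannot be swapped for phenyl without a loss of inhibition on this read-out. The step gives only a minimum size, and its true size stays unknown: the limit of > 100000 nM in this assay, at which 1 of the 3 values shown sits.

On these data alone, whether a longer chain such as phenethyl on the same nitrogen would lower or raise the number remains open. Compound 2 is linked to neither compound 1 nor compound 3 by a single change, so what its methoxy groups contribute also cannot be read.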